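Chloro Substitution on Two Cyanoacrylamide Cores

A few compounds are considered here, and "the series" means these few. Any claim that something is new, unique, unknown or untested is made for them only; others in the source may bear on it.

Measured compounds:
- compound 1, `COc1ccc(CNC(=O)/C(C#N)=C/c2ccco2)cc1`: 22000 nM
- compound 2, `COc1ccc(CNC(=O)/C(C#N)=C/c2ccc(Cl)o2)cc1`: 9000 nM
- compound 3, `N#C/C(=C\c1ccccc1)C(=O)NCc1ccc(Cl)c(Cl)c1`: 70000 nM

The three measured compounds were tested in a functional assay on HT-29 cells (Homo sapiens) for inhibition, read by MTT assay, with a stated time of 72 h; on this read-out lower numbers stand for stronger inhibition of growth and higher numbers for weaker inhibition of growth. Compound 1 gives 22000 nM and compound 2 gives 9000 nM, so the step of a 2.4-fold lower number from compound 1 to compound 2 (0.39 log units; beyond the scatter) is the only counted one in the set. The change behind it is chloro in place of hydrogen on an aromatic carbon. Compound 3, in this assay, gives 70000 nM, the highest number of the three. How the core of compound 3 differs from the core of compound 1 is not broken down here.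

Compound 4, `N#C/C(=C\c1ccc(Cl)cc1)C(=O)NCc1ccc(Cl)c(Cl)c1`, has not yet been measured. It differs from compound 3 by chloro in place of hydrogen on an aromatic carbon. For the measured compounds named here, this is the same kind of change as the one from compound 1 to compound 2, but not the same: in compound 2 the chloro sits on a five-membered aromatic ring with one oxygen, next to the ring oxygen, two ring bonds from the ring atom that bears a large group, whereas in compound 4 it sits on a six-membered aromatic ring of carbon only, para to a large group. Given this, and given that the one measured step of this kind is a 2.4-fold lower number from compound 1 to compound 2 (0.39 log units; beyond the scatter), a step of similar modest size is expected from compound 3 to compound 4, namely a 2.1-fold lower number from compound 3 to compound 4 (0.33 log units; beyond the scatter). Compound 4 is therefore estimated at 33000 nM in this assay, between 12000 nM and 90000 nM.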

Compound 4, concentration for 50% growth inhibition: 33000 nM
Beside the measured number, compound 4's estimate shows no gap at the digits printed, and the stated range covers the measured number.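

In this assay, the new measurement gives a 2.1-fold lower number from compound 3 to compound 4 (0.33 log units; beyond the scatter), which places a second chloro-for-hydrogen step beside the first, and the two agree in size: the same change on two cores in this assay, a 2.4-fold lower number (0.39 log units; beyond the scatter) from compound 1 to compound 2 and a 2.1-fold lower number (0.33 log units; beyond the scatter) from compound 3 to compound 4, 1.2-fold (0.06 log units) apart, within the scatter of two such steps. In these two pairs, then, the change carried from one core to the other with a step of matching size, although in compound 4 the chloro stands on a six-membered aromatic ring of carbon only and in compound 2 it stands on a different kind of ring. For the compounds shown here, this is still only two pairs in a single cell growth read-out, so it does not show that the step would hold on any other core or at any other place on these rings, and it gives no explanation of why the step has this size.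

The compounds shown leave open whether a bromo group, an amine or a carboxylic acid on that same aromatic carbon would give a step of similar size to chloro. They also leave open whether the chloro step would persist if the group on the amide nitrogen were replaced by a longer chain, or whether a second chloro on the same ring would add a further step.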